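The source may hold more compounds than are shown below. What is called first, only, known or untested is meant among the compounds shown, and "the series" means these compounds.

The account concerns two measured compounds and one that awaits measurement in an assay on HEK293 cells for inhibition of Steryl-sulfatase (Homo sapiens), tested at 1 uM; a higher number here means a stronger effect of the compound at the concentration tested, a lower number a weaker effect. Compound 1 `CN(C)CCCN(Cc1ccccc1)c1cccc(C(=O)N2CCc3ccc(OS(N)(=O)=O)cc3C2)c1` gives 26% in this assay. Compound 2 `CCN(Cc1cccnc1)c1ccc(C(=O)N2CCc3ccc(OS(N)(=O)=O)cc3C2)cc1` gives 85.2% in this assay, the higher of the two numbers, and its gap to compound 1 lies beyond the scatter. Compound 3 `CN(CCN1CCCCC1)c1ccc(C(=O)N2CCc3ccc(OS(N)(=O)=O)cc3C2)cc1` differs from compound 2 in a single place: methyl(2-(piperidin-1-yl)ethyl)amino in place of ethyl((pyridin-3-yl)methyl)amino on an aromatic carbon. Within the data shown here, no step between measured compounds that differ in only one place is available, so the size of this change cannot be read from any direct pair. Compound 1, at 26%, shows only that not every substitution pattern on the shared core keeps the high number, which tilts the expectation downward. The step expected from compound 2 to compound 3 is a number 25.2 percentage points lower from compound 2 to compound 3 (beyond the scatter), a decrease beyond the scatter. Compound 3 is estimated at 60%, with a range from 30% to 88%.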

Compound 3, a percentage reported as inhibition, at one concentration (the size of the read-out at that concentration, not a potency): 26.8%
The estimate for compound 3 lay 33.2 percentage points above the measured number; the measured number lies below the stated range.
By their numbers in this assay, from the lowest: compounds 1 and 3 (each within the scatter of the next); then compound 2.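

In this assay, placing methyl(2-(piperidin-1-yl)ethyl)amino in place of ethyl((pyridin-3-yl)methyl)amino on an aromatic carbon para to a large group gives a number 58.4 percentage points lower from compound 2 to compound 3 (beyond the scatter). This is the only direct pair shown at this position, and it shows that the read-out depends strongly on the group there, even though the two groups match in their counts of heavy atoms, hydrogen-bond donors and hydrogen-bond acceptors. Nothing available explains the size of this step.

This one pair does not separate the exchange of the aromatic ring for the non-aromatic ring from the differences in the chain that carries it and in the other group on the nitrogen. Going by these compounds, how a morpholine ring at the end of the same ethyl chain would behave at this position remains open.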